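Chloro Added to a Weak Growth Inhibitor

The source may hold more compounds than are shown below. What is called first, only, known or untested is meant among the compounds shown, and "the series" means these compounds.

compound 1 `Cc1ccc2nc(/N=C3\C(=O)N(CN(c4ccccc4)c4ccccc4)c4ccccc43)sc2c1`: 34100 nM
compound 2 `Cc1ccc2nc(/N=C3\C(=O)N(CN4CCCCC4)c4cccc(Br)c43)sc2c1`: 38300 nM

In a functional assay on MDA-MB-231 cells (Homo sapiens) for cytotoxicity, read by sulforhodamine B assay, with a stated time of 48 h (a higher number here means a weaker inhibitor of growth, a lower number a stronger inhibitor of growth), compound 1 gives 34100 nM. Compound 2 gives 38300 nM, so compound 1 stands alongside it, the two numbers lying within the usual scatter of each other. Compound 3 `Cc1ccc2nc(/N=C3\C(=O)N(CN(c4ccccc4)c4ccccc4)c4cccc(Cl)c43)sc2c1` differs from compound 1 by chloro in place of hydrogen on an aromatic carbon. Among the compounds with values here, no step between two measured compounds informs this change, so the step is expected to be small, with no direction beyond the scatter; the expected step is a 1.1-fold lower number from compound 1 to compound 3 (0.06 log units; within the scatter). Compound 3 is therefore estimated at 30000 nM, with a range from 10000 nM to 90000 nM.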

Compound 3, concentration for 50% growth inhibition: 54000 nM
Estimate against measurement, compound 3: 1.8-fold (0.26 log units) below; measured number inside the range.
By their numbers in this assay, from the lowest: compounds 1, 2 and 3 (each within the scatter of the next).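

In this assay, chloro in place of hydrogen on this aromatic carbon, ortho to a fused ring and meta to a fused ring, gives a 1.6-fold higher number from compound 1 to compound 3 (0.20 log units; within the scatter). This single change therefore leaves compound 3 indistinguishable from compound 1, so this position tolerates chloro without a shift that can be told from the scatter. No evidence at hand bears on this result. The compounds shown leave open whether a larger or different group at this carbon, such as an amine or a carboxylic acid, would separate from hydrogen.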